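Fluorine on a Phenyl Ring and Microsomal Stability

This account rests on a few compounds, and the source may have more. Where it says the series, first, only, none or still open, it means among the compounds named here.

Three compounds were measured in an ADME assay on microsomes from liver (Mus musculus) for metabolic stability, with a stated time of 10 min, tested at 0.5 uM; a higher number here means that more of the compound is left, a lower number that less of the compound is left. Compound 1, `Cc1noc(C)c1[C@@H]1C[C@@](C)(c2ccccc2)N=C(N)S1`, leaves 78% after the incubation. Compound 2, `Cc1noc(C)c1[C@@H]1C[C@@](C)(c2ccc(F)cc2)N=C(N)S1`, differs from compound 1 only by fluoro in place of hydrogen on an aromatic carbon, and in this assay compound 2 leaves 90%. That single change gave a number 12 percentage points higher from compound 1 to compound 2 (beyond the scatter). Compound 3, `Cc1noc(-c2ccccc2)c1[C@@H]1C[C@@](C)(c2ccc(F)cc2F)N=C(N)S1`, carries a phenyl group on the other ring in place of a methyl group and a second fluorine on the first phenyl ring; in this assay compound 3 leaves 6%, the lowest of the three numbers. How the core of compound 3 differs from the core of compound 1 is not broken down here.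

Compound 4, `Cc1noc(-c2ccc(F)cc2)c1[C@@H]1C[C@@](C)(c2ccc(F)cc2F)N=C(N)S1`, has not yet been measured. Within the data shown here, it differs from compound 3 by fluoro in place of hydrogen on an aromatic carbon, which is the same change as the one from compound 1 to compound 2. Because that earlier change gave a number 12 percentage points higher from compound 1 to compound 2 (beyond the scatter), a modest rise of the same kind is expected from compound 3 to compound 4, in this assay estimated as a number 8 percentage points higher from compound 3 to compound 4 (within the scatter). The expectation rests on a single measured pair, and the two starting points sit far apart, so the estimate is held wide. Compound 4 is expected to leave about 14% in this assay, most likely between 3% and 32%.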

Compound 4, percent of the compound remaining: 53%
Estimate against measurement, compound 4: 39 percentage points below; the whole stated range lies below it.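

The swap from phenyl to 4-fluorophenyl gave, in this assay, a number 47 percentage points higher from compound 3 to compound 4 (beyond the scatter). Set beside the earlier example of fluoro in place of hydrogen, this shows that the direction of the change carried over from one core to the other, while its size did not: the same change on two cores in this assay, a number 12 percentage points higher (beyond the scatter) from compound 1 to compound 2 and a number 47 percentage points higher (beyond the scatter) from compound 3 to compound 4, 35 percentage points apart, beyond the scatter of two such steps

Among these compounds, this does not show how large the step would be on a third core, or why it was larger here: there are only two pairs, they start from very different values, with compound 1 at 78% and compound 3 at 6%, and the fluorine enters a different phenyl ring in each pair, so the effects of the starting value, the core and the ring that is changed cannot be separated.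

The compounds shown leave open whether chloro, methoxy or an amine in the same place on the ring would raise the number as fluoro does. They also leave open whether a methyl group in place of the 4-fluorophenyl group, with the rest of compound 4 unchanged, would leave more of the compound than the aryl groups do.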